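A few compounds are considered here, and "the series" means these few. Any claim that something is new, unique, unknown or untested is made for them only; others in the source may bear on it.

In an ADME assay for solubility (a lower number here means a less soluble compound, a higher number a more soluble compound), compound 1 `CCCCCCCCCCCCCCCCSCC(COP(=O)(O)OP(=O)(O)OC[C@H]1OC(n2ccc(N)nc2=O)[C@@H](O)[C@@H]1O)OC(=O)CCCCCCCCCCCCCCC` gives 200000 nM. Compound 2 `CCCCCCCCCCCCCCSCC(COP(=O)(O)OP(=O)(O)OC[C@H]1OC(n2ccc(N)nc2=O)[C@@H](O)[C@@H]1O)OC(=O)CCCCCCCCCCC` returns only a limit of this assay, > 50000000 nM, not a measured number. That reading is the one marked by the limit of > 50000000 nM in this assay, at which 1 of the 2 values shown sits. Compound 3 `CCCCCCCCCCCCCCCCSCC(COP(=O)(O)OP(=O)(O)OC[C@H]1OC(n2ccc(N)nc2=O)[C@@H](O)[C@@H]1O)OC(=O)CCCCCCCCCCC` is not yet measured; it differs from compound 2 by ethyl in place of hydrogen on a saturated chain carbon, ten or more bonds along the chain from a sulfur, with the shared core unchanged. Compound 1 carries the longer chains and shows the smaller number of the two measured values. For compound 3 a step downward, toward a measurable value, is expected: an at least 5.0-fold lower number from compound 2 to compound 3 (0.69 log units; beyond the scatter). The estimate for compound 3 is 10000000 nM, within a range from 1000000 nM to 60000000 nM.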

Compound 3, solubility: > 64000000 nM
Compound 3: only a limit was reported; the forecaster's own chance of this, stated with the estimate: 35%; middle value at least 6.4-fold (0.80 log units) from the limit.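

In this assay compound 3 gives > 64000000 nM as a limit and not a number. Compound 2 also stands at a limit, so the step between the two cannot be read, and the ethyl change shows nothing measurable. Hydrogen in place of butyl on a saturated chain carbon gives an at least 320-fold higher number from compound 1 to compound 3 (2.50 log units; beyond the scatter) and is the first readable step here.

From the compounds shown here alone, the real distance between compound 2 and compound 3 stays open. So does how an amine or a carboxylic acid on either chain would read.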